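Ester Tail Swap: Glycol Ether Gives Way to Carbamoyl

This account rests on a few compounds, and the source may have more. Where it says the series, first, only, none or still open, it means among the compounds named here.

Compounds with measured values:
compound 1, `CCOc1cc(NC(=O)C2(NC(=O)c3ccc4c(C5CCCC5)c(-c5ncc(Cl)cn5)n(C)c4c3)CCC2)ccc1/C=C/C(=O)OCC(Cl)(Cl)Cl`, in an ADME assay (liver) for pharmacokinetics, with Liver microsome (Homo sapiens) as the target, using microsomes (on this read-out lower numbers stand for a shorter-lived compound and higher numbers for a longer-lived compound), gives > 5 h, a limit of the assay rather than a number.
compound 2, `CCOc1cc(NC(=O)C2(NC(=O)c3ccc4c(C5CCCC5)c(-c5ncc(Cl)cn5)n(C)c4c3)CCC2)ccc1/C=C/C(=O)OCCOCCOC`, in this assay gives 0.85 h.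

Compound 2 therefore carries the only number shown; the one other value is a limit (the limit of > 5 h in this assay, at which 1 of the 2 values shown sits). Among the compounds with values here, the single measured step, an at least 5.8-fold lower number from compound 1 to compound 2 (0.76 log units; beyond the scatter), is beyond the scatter and runs downward.

Compound 3, `CCOc1cc(NC(=O)C2(NC(=O)c3ccc4c(C5CCCC5)c(-c5ncc(Cl)cn5)n(C)c4c3)CCC2)ccc1/C=C/C(=O)OCC(N)=O`, differs from compound 2 by carbamoyl in place of (2-methoxyethoxy)methyl on a saturated chain carbon bound to an oxygen next to a carbonyl group. Within the data shown here, the measured step bears on this change only in part: it shows that the (2-methoxyethoxy)methyl tail of compound 2 sits at a lower number than the trichloromethyl tail of compound 1, but no measured pair covers the carbamoyl group itself. Removing the tail that accompanied the downward step leaves the direction for compound 3 open, so only a modest step is expected, leaning upward, as a 1.8-fold higher number from compound 2 to compound 3 (0.25 log units; within the scatter).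

Compound 3 is thus estimated in this assay at 1.5 h, between 0.5 h and 4.5 h.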

Compound 3, half-life: 0.983 h
Estimate against measurement, compound 3: 1.5-fold (0.18 log units) above, within the range that was stated.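

On a saturated chain carbon bound to an oxygen next to a carbonyl group, carbamoyl and (2-methoxyethoxy)methyl cannot be told apart in this assay (a 1.2-fold higher number from compound 2 to compound 3 (0.06 log units; within the scatter)), even though carbamoyl has 3 heavy atoms against 6 and brings a hydrogen-bond donor. The drop first seen with the glycol ether tail is therefore not unique to that tail, as the carbamoyl group shows a step of similar standing, beyond the scatter (an at least 5.0-fold lower number from compound 1 to compound 3 (0.70 log units; beyond the scatter)), so among these three esters only the trichloromethyl tail of compound 1 stands apart. The size of that step is only a lower bound, since the value of compound 1 is a limit and not a number: the limit of > 5 h in this assay, at which 1 of the 3 values shown sits.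

Three tails cannot show whether the long half-life of compound 1 belongs to the trichloromethyl group alone or would also appear with a trifluoromethyl group, a single chlorine or a plain methyl group at this place. On these data alone, it also remains open where a carboxylic acid, an amine or a longer chain would fall on this read-out.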